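Aryl-amine variation on the shared core: estimate for compound 3

A few compounds are considered here, and "the series" means these few. Any claim that something is new, unique, unknown or untested is made for them only; others in the source may bear on it.

Measured so far in a functional assay on CCRF-CEM cells for antagonist activity at C-X-C chemokine receptor type 4 (Homo sapiens), read by calcium flux, with stated times of 25 min and 90 s; on this read-out higher numbers stand for weaker inhibition and lower numbers for stronger inhibition:
compound 1 `CN(C[C@H]1Cc2c(cccc2N2C[C@@H]3C[C@H]2CN3)CN1)[C@H]1CCCc2cccnc21` — 146 nM
compound 2 `CN1CCN(c2cccc3c2C[C@H](CN(C)[C@H]2CCCc4cccnc42)NC3)CC1` — 29.6 nM

Compound 2 holds the lowest of the two numbers; its nearest neighbour is compound 1, and the step of a 4.9-fold lower number from compound 1 to compound 2 (0.69 log units; beyond the scatter) lies beyond the scatter. That single step is the only one bearing on the position now varied: it exchanges one group on the aromatic carbon for another and is modest in size.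

Compound 3 `CN(C[C@H]1Cc2c(cccc2N2CCN3CCC[C@H]3C2)CN1)[C@H]1CCCc2cccnc21` is not yet measured. It differs from compound 2 by a group of 9 heavy atoms (7 carbon, 2 nitrogen; one five-membered non-aromatic ring with 1 hetero atom, one six-membered non-aromatic ring with 2 hetero atoms) in place of a group of 7 heavy atoms (5 carbon, 2 nitrogen; one six-membered non-aromatic ring with 2 hetero atoms), on an aromatic carbon. The entering group again carries two ring systems at the place where compound 1 carries its two-ring group, so a return toward the number of compound 1 is expected rather than a further fall. The expected step is a 2.0-fold higher number from compound 2 to compound 3 (0.31 log units; beyond the scatter), a modest rise that may not clear the scatter. Compound 3 is estimated at 60 nM, with a range from 20 nM to 200 nM.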

Compound 3, half-maximal inhibitory concentration: 2.92 nM
For compound 3 the middle estimate is 21-fold (1.31 log units) above the measured one, and the stated range ends above it.
By their numbers in this assay, from the lowest: compound 3; then compound 2; then compound 1.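

In this assay, this position on the aromatic carbon proves far more sensitive than the first step suggested: replacing 4-methylpiperazin-1-yl with the group carrying a five-membered and a six-membered non-aromatic ring gives a 10-fold lower number from compound 2 to compound 3 (1.01 log units; beyond the scatter), and replacing the group of compound 1 with it gives a 50-fold lower number from compound 1 to compound 3 (1.70 log units; beyond the scatter). Carrying two rings therefore does not by itself set the number, as compound 1 and compound 3 both carry two rings yet stand at opposite ends of the series. Nothing available explains the size of either step.

It remains open whether the defined stereocentre of the entering group contributes, as no pair shown isolates it. It is also unclear how morpholin-4-yl or an open-chain dimethylamino group would compare at this position.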